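Ethoxycarbonyl in place of benzyl on the shared core

This account rests on a few compounds, and the source may have more. Where it says the series, first, only, none or still open, it means among the compounds named here.

Of the compounds shown here, three with a shared core have been read in an ADME assay on S9 fraction from liver (Rattus norvegicus) for metabolic stability, read by LC-MS, using NADPH, with a stated time of 30 min; a higher number here means that more of the compound is left, a lower number that less of the compound is left. Compound 1 `CCCCCCCCc1ccc(OCC(=O)Cn2nnnc2-c2ccccc2)cc1` gives 36%. Compound 2 `CCCCCCCCc1ccc(OCC(=O)Cn2nnnc2-c2ccccn2)cc1` gives < 5%, which is a limit of the assay and not a number. Compound 3 `CCCCCCCCc1ccc(OCC(=O)Cn2nnnc2Cc2ccccc2)cc1` gives 26%, which places it within the usual scatter of compound 1 and clearly apart from compound 2.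

Compound 4 `CCCCCCCCc1ccc(OCC(=O)Cn2nnnc2C(=O)OCC)cc1` carries ethoxycarbonyl in place of the benzyl of compound 3 on an aromatic carbon (ethoxycarbonyl in place of benzyl on an aromatic carbon). Earlier changes at this same carbon gave mixed results. Benzyl for phenyl gave a number 10 percentage points lower from compound 1 to compound 3 (within the scatter), while pyridin-2-yl for phenyl gave a number at least 31 percentage points lower from compound 1 to compound 2 (beyond the scatter). Going on to benzyl from pyridin-2-yl gave a number at least 21 percentage points higher from compound 2 to compound 3 (beyond the scatter). Among the measured compounds shown here, no measured compound carries ethoxycarbonyl, so these steps only show that this carbon can matter a great deal. A modest downward move is expected, and the estimate is a number 12 percentage points lower from compound 3 to compound 4 (beyond the scatter). For compound 4 the estimated value is 14%, with an expected range from 5% to 32%.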

Compound 4, percent of the compound remaining: 33%
Compound 4: middle estimate off by 19 percentage points, on the low side; measured number outside the range, above it.
By their numbers in this assay, from the lowest: compounds 3, 4 and 1 (each within the scatter of the next). At a limit, below all of these: compound 2.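

Ethoxycarbonyl in place of benzyl gives a number 7 percentage points higher from compound 3 to compound 4 (within the scatter), and ethoxycarbonyl in place of phenyl gives a number 3 percentage points lower from compound 1 to compound 4 (within the scatter), so in this assay a group with no ring and with two hydrogen-bond acceptors reads level with both of these ring-bearing groups. Pyridin-2-yl remains the one group apart, with a number at least 28 percentage points higher from compound 2 to compound 4 (beyond the scatter), which shows that a ring on this carbon is not needed to stay clear of the reading of compound 2. Compound 2 stands at a limit and not at a number: the limit of < 5% in this assay, at which 1 of the 4 values shown sits.

Which part of ethoxycarbonyl counts, the carbonyl or the ethyl end, cannot be told from these compounds. They also leave open how an amine, a carboxylic acid or a longer chain on this carbon would read.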